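The source may report more compounds than this note shows. Statements on the series, on what has been measured and on what is new or still open speak of the compounds shown alone.

Of the compounds shown here, two have been read so far in an in vitro ADME assay on microsomes from liver (Homo sapiens) for metabolic stability; on this read-out lower numbers stand for slow clearance and higher numbers for fast clearance. For compound 1 `Cc1nnc(C2CCN(c3ccccn3)CC2)n1-c1ccccc1` the read-out is only a limit: < 8 mL.min-1.g-1. Among the compounds with values here, compound 2 `CCOCc1nnc(C2CCN(c3ccccn3)CC2)n1Cc1ccccc1` gives 23 mL.min-1.g-1 in this assay, and this is the only actual number available for the series.

Compound 3 `c1ccc(Cn2c(Cn3nccn3)nnc2C2CCN(c3ccccn3)CC2)cc1` keeps the rest of compound 2 and changes one group: 2H-1,2,3-triazol-2-yl in place of ethoxy on a saturated chain carbon bound to an aromatic carbon. In words, 2H-1,2,3-triazol-2-yl stands in place of ethoxy on a saturated chain carbon bound to an aromatic carbon. The same difference, read one bond further out, is ethoxymethyl to (2H-1,2,3-triazol-2-yl)methyl.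

Within the data shown here, no two measured compounds differ in one place only, and no measured step speaks to this exchange. A move beyond the usual scatter is not expected in this assay, only a small lean toward slower clearance, with a 1.3-fold lower number from compound 2 to compound 3 (0.11 log units; within the scatter) as the estimated step. Among the measured compounds shown here, the expectation is anchored on compound 2 at 23 mL.min-1.g-1 as the sole number in hand. For compound 3 the expected intrinsic clearance is 18 mL.min-1.g-1, with an estimated range of 8 mL.min-1.g-1 to 40 mL.min-1.g-1.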

Compound 3, intrinsic clearance in microsomes: 19 mL.min-1.g-1
The estimate for compound 3 lay 1.1-fold (0.02 log units) below the measured number; the measured number falls inside the stated range.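

In this assay, within the data shown here, 2H-1,2,3-triazol-2-yl in place of ethoxy on a saturated chain carbon bound to an aromatic carbon gives a 1.2-fold lower number from compound 2 to compound 3 (0.08 log units; within the scatter), the first step that differs in one place only. This position therefore takes the five-membered aromatic ring, with its larger heavy-atom count and additional hydrogen-bond acceptors, without a move in intrinsic clearance beyond the usual scatter, so ethoxymethyl and (2H-1,2,3-triazol-2-yl)methyl cannot be told apart on this read-out. Nothing measured in hand bears on a cause for this step.

Among these compounds, compound 1 gives < 8 mL.min-1.g-1 in this assay, which is a limit of the assay and not a number, and it differs from compound 2 in more than one place, so it gives no step. On these data alone, whether a dimethylamino group or a carboxylic acid in the same place would shift the number beyond the scatter stays open, as does whether the same exchange would read alike on the core of compound 1.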